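A few compounds are considered here, and "the series" means these few. Any claim that something is new, unique, unknown or untested is made for them only; others in the source may bear on it.

Of the compounds shown here, three of one family have been measured so far. Compound 1 `CC[C@@H]1/C=C(\C)C[C@H](C)C[C@H](OC)[C@H]2O[C@@](O)(C(=O)C(=O)N3CCCC[C@H]3C(=O)O[C@H](/C(C)=C/[C@@H]3CC[C@@H](Oc4cccc(C)c4)[C@H](OC)C3)[C@H](C)[C@@H](O)CC1=O)[C@H](C)C[C@@H]2OC` carries a 3-methylphenoxy group. Compound 2 `CC[C@@H]1/C=C(\C)C[C@H](C)C[C@H](OC)[C@H]2O[C@@](O)(C(=O)C(=O)N3CCCC[C@H]3C(=O)O[C@H](/C(C)=C/[C@@H]3CC[C@@H](Oc4ccccc4)[C@H](OC)C3)[C@H](C)[C@@H](O)CC1=O)[C@H](C)C[C@@H]2OC` carries a plain phenoxy group, and compound 3 `CC[C@@H]1/C=C(\C)C[C@H](C)C[C@H](OC)[C@H]2O[C@@](O)(C(=O)C(=O)N3CCCC[C@H]3C(=O)O[C@H](/C(C)=C/[C@@H]3CC[C@@H](Oc4ccccc4)[C@H](O)C3)[C@H](C)[C@@H](O)CC1=O)[C@H](C)C[C@@H]2OC` keeps that phenoxy group but has a hydroxy where compound 2 has a methoxy. Compound 4 `CC[C@@H]1/C=C(\C)C[C@H](C)C[C@H](OC)[C@H]2O[C@@](O)(C(=O)C(=O)N3CCCC[C@H]3C(=O)O[C@H](/C(C)=C/[C@@H]3CC[C@@H](Oc4ccc(C)cc4)[C@H](O)C3)[C@H](C)[C@@H](O)CC1=O)[C@H](C)C[C@@H]2OC` has not been measured yet.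

In a functional assay on cells for inhibition, with Murine T-cell line (Mus musculus) as the target (on this read-out lower numbers stand for stronger inhibition and higher numbers for weaker inhibition), compound 1 gives 5.4 nM. In this assay compound 2 gives 5.4 nM, and compound 3 gives 5.2 nM. The three numbers sit close together, and none of them can be called stronger or weaker than another. Going from compound 2 to compound 1, the change is methyl in place of hydrogen on an aromatic carbon, and the result is no change at the digits printed from compound 2 to compound 1 (within the scatter). Going from compound 2 to compound 3, the change is hydrogen in place of methyl on an oxygen on a saturated carbon, and the result is a 1.0-fold lower number from compound 2 to compound 3 (0.02 log units; within the scatter); this is also how the core of compound 3 differs from the core of compound 2.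

Compound 4 arises from compound 3 by methyl in place of hydrogen on an aromatic carbon. Within the data shown here, this is the same kind of change as the one from compound 2 to compound 1, but not the same: in compound 1 the methyl sits meta to a large group, in compound 4 para to a large group. Because the earlier step was no change at the digits printed from compound 2 to compound 1 (within the scatter), the step expected from compound 3 to compound 4 is a 1.0-fold higher number from compound 3 to compound 4 (0.01 log units; within the scatter). Compound 4 is therefore estimated at 5.3 nM, expected to fall between 2.5 nM and 11 nM.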

Compound 4, half-maximal inhibitory concentration: 6 nM
Estimate against measurement, compound 4: 1.1-fold (0.05 log units) below, and the stated range covers the measured number.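

In this assay, placing a methyl on the aromatic ring of the phenoxy group gives a 1.2-fold higher number from compound 3 to compound 4 (0.06 log units; within the scatter), so this step, like the earlier one, stays within the usual scatter of the measurement. Set side by side, the two steps agree, which means that in these compounds the methyl leaves the read-out just as flat on the core with the methoxy as on the core with the hydroxy: the same change on two cores in this assay, no change at the digits printed (within the scatter) from compound 2 to compound 1 and a 1.2-fold higher number (0.06 log units; within the scatter) from compound 3 to compound 4, 1.2-fold (0.06 log units) apart, within the scatter of two such steps This does not show that the effect of a change carries over between cores in general, since both steps are too small to reveal any real effect that could either carry over or fail to, and the comparison also mixes two differences, the core and the place of the methyl, which belongs to a 3-methylphenoxy group in compound 1 and a 4-methylphenoxy group in compound 4.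

The compounds shown leave open whether a group other than methyl on this aromatic ring, such as a chlorine atom, an amine or a carboxylic acid, would also leave the number where it is. As far as these compounds go, it also remains open what a longer chain in place of the phenoxy group would do on either core.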